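One Stereocentre Changed, Cytotoxicity Compared

The compounds below may be only part of what the source reports. "The series", "measured", "known", "first", "only" and "open" are said of these compounds alone.

Compound 1 `CCOC(=O)[C@@H]1C[C@@]23CN(C)C[C@@H](CCC4=C2[C@H]1CC4=O)C31CC[C@](CC)(OC)OC1` and compound 2 `CCO[C@@]1(CC)CCC2(CO1)[C@@H]1CCC3=C4[C@H](CC3=O)[C@H](C(=O)OC)C[C@@]42CN(C)C1` are close relatives built on the same kind of core. In a functional assay on MCF7 cells (Homo sapiens) for cytotoxicity, read by MTT assay, with a stated time of 48 h (on this read-out lower numbers stand for stronger inhibition and higher numbers for weaker inhibition), compound 1 gives only a limit, > 40000 nM. Compound 2 likewise gives only a limit in this assay, > 40000 nM. Both values therefore sit at the edge of what the assay can report (the limit of > 40000 nM in this assay, at which 2 of the 2 values shown sit). Compound 3 `CCO[C@@]1(CC)CCC2(CO1)[C@@H]1CCC3=C4[C@@H](CC3=O)[C@H](C(=O)OC)C[C@@]42CN(C)C1` is not yet measured; it differs from compound 2 only in stereochemistry: the two compounds have the same atoms and bonds; at least one stereo element is drawn with a configuration in one of them and without one in the other: 1 of 6 stereo elements differ; a stereocentre at a saturated ring carbon is drawn R in compound 2 and S in compound 3. Among the compounds with values here, with no measured step to guide it, the expectation for compound 3 is no change beyond the scatter, a step that the limit leaves unreadable from compound 2 to compound 3. Compound 3 is thus expected at 60000 nM, between 25000 nM and 150000 nM.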

Compound 3, half-maximal inhibitory concentration: > 40000 nM
Compound 3: a limit, no number; the forecaster's own chance of this, stated with the estimate: 85%; the middle value is on the limit's open side.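

Compound 2 and compound 3 both give only a limit in this assay, so no step between them can be read: the limit of > 40000 nM in this assay, at which 3 of the 3 values shown sit.

What the compounds shown leave open is whether the stereocentre drawn R in compound 2 and S in compound 3 has any bearing on cytotoxicity.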